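The compounds below may be only part of what the source reports. "The series", "measured", "known", "first", "only" and "open" are said of these compounds alone.

Working notes on the series. In an assay on cells for inhibition of matrix metalloproteinase-9 (Homo sapiens), read by fluorescence, with stated times of 15 min and 4 h (on this read-out higher numbers stand for weaker inhibition and lower numbers for stronger inhibition), compound 1 `Cc1ccc2nc(-c3ccc(NC(=O)CCc4ccccc4)cc3)[nH]c2c1` gives 60000 nM. Compound 2 `O=C(CCc1ccccc1)Nc1ccc(-c2nc3ccc(Br)cc3[nH]2)cc1` carries the same amide chain on a core that differs from compound 1 only by methyl in place of bromo on an aromatic carbon; in this assay compound 2 gives 11500 nM, and the change produces a 5.2-fold higher number from compound 2 to compound 1 (0.72 log units; beyond the scatter). Compound 3 `O=[N+]([O-])c1ccc(-c2nc3ccc(Br)cc3[nH]2)cc1` bears a nitro group in place of that chain; in this assay compound 3 gives 10000 nM, a number that sits within the scatter of compound 2, so no order between compound 3 and compound 2 is claimed. The difference between the core of compound 3 and the core of compound 2 is not broken down here. Compound 4 `Cc1ccc2nc(-c3ccc([N+](=O)[O-])cc3)[nH]c2c1` is not yet measured; it arises from compound 3 by methyl in place of bromo on an aromatic carbon, the same change as from compound 2 to compound 1, with the place described in the same words. On a single prior instance only, the expected step from compound 3 to compound 4 is a 5.0-fold higher number from compound 3 to compound 4 (0.70 log units; beyond the scatter), resting on a 5.2-fold higher number from compound 2 to compound 1 (0.72 log units; beyond the scatter). Compound 4 is accordingly expected to give about 50000 nM in this assay, estimated between 20000 nM and 120000 nM.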

Compound 4, half-maximal inhibitory concentration: 22000 nM
The estimate for compound 4 lay 2.3-fold (0.36 log units) above the measured number, and the stated range covers the measured number.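

In this assay the replacement of bromo by methyl again goes toward weaker inhibition, giving a 2.2-fold higher number from compound 3 to compound 4 (0.34 log units; beyond the scatter), so the direction of the change is the same on both cores shown. The sizes of the two steps cannot be told apart: the same change on two cores in this assay, a 5.2-fold higher number (0.72 log units; beyond the scatter) from compound 2 to compound 1 and a 2.2-fold higher number (0.34 log units; beyond the scatter) from compound 3 to compound 4, 2.4-fold (0.38 log units) apart, within the scatter of two such steps. This supports carrying the change between the core with the amide chain and the core with the nitro group, but it rests on two pairs only, says nothing about any other core, and gives no reason for the direction or size of the step.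

The compounds shown leave open whether other groups on the same aromatic carbon, such as chloro, an amine or a carboxylic acid, would fall in line with bromo or with methyl. They also leave open whether the step keeps its direction and size when an amine, a carboxylic acid or a longer chain stands in place of the amide chain or the nitro group.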